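The source may hold more compounds than are shown below. What is called first, only, known or untested is meant among the compounds shown, and "the series" means these compounds.

Measured in an ADME assay on microsomes from liver (Homo sapiens) for metabolic stability, read by LC-MS, with a stated time of 30 min, tested at 1 uM; a higher number here means that more of the compound is left, a lower number that less of the compound is left:
compound 1 `O=C(NCc1ccc(S(=O)(=O)c2cc(F)cc(F)c2)cc1)c1cnc2nccn2c1`: 78%
compound 2 `O=C(NCc1ccc(S(=O)(=O)c2cccc(C(F)(F)F)c2)cc1)c1cc2ccncc2o1`: 48%

Compound 2 (48%) holds the lower of the two numbers, and compound 1 (78%) stands above it, beyond the scatter. Compound 3 `O=C(NCc1ccc(S(=O)(=O)c2cccc(C(F)(F)F)c2)cc1)c1cnc2nccn2c1` differs from compound 2 in one place, on a carbonyl carbon whose other neighbours are: amide-type nitrogen (a group of 9 heavy atoms (6 carbon, 3 nitrogen; one five-membered aromatic ring with 2 hetero atoms, one six-membered aromatic ring with 2 hetero atoms) in place of a group of 9 heavy atoms (7 carbon, 1 nitrogen, 1 oxygen; one five-membered aromatic ring with 1 hetero atom, one six-membered aromatic ring with 1 hetero atom), on a carbonyl carbon). For the measured compounds named here, no pair of measured compounds differs in one place only, so no measured step guides this change directly. The entering group is also carried by compound 1, which gives 78% in this assay, but that number is only a partial guide to compound 3. An upward step beyond the scatter is therefore expected in this assay (a number 20 percentage points higher from compound 2 to compound 3 (beyond the scatter)). Compound 3 is estimated at 68% in this assay, with an expected range from 52% to 84% (an estimate only, with the measurement still to come).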

Compound 3, percent of the compound remaining: 41%
Compound 3: middle estimate off by 27 percentage points, on the high side; measured number below the stated range.
By their numbers in this assay, from the lowest: compounds 3 and 2 (each within the scatter of the next); then compound 1.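

In this assay, the change on the carbonyl carbon gives a number 7 percentage points lower from compound 2 to compound 3 (within the scatter), so with 3-(trifluoromethyl)phenyl on the sulfonyl sulfur, this read-out does not separate the two groups at that place. The change on the sulfonyl sulfur, 3-(trifluoromethyl)phenyl in place of 3,5-difluorophenyl, gives a number 37 percentage points lower from compound 1 to compound 3 (beyond the scatter), which shows that the group on the carbonyl carbon shared by compound 1 and compound 3 does not alone carry the number of compound 1, and that in this pair the substituent on the sulfonyl sulfur makes the difference. No measurement at hand gives a reason for either step.

As far as these compounds go, it remains open whether the step on the sulfonyl sulfur would keep its size with the group of compound 2 on the carbonyl carbon, and how a plain phenyl or a 3-chlorophenyl on the sulfonyl sulfur would stand against the two groups seen there so far. With only the amount of compound left reported in this assay, it also remains open which part of these compounds changes during the incubation.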